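Cytotoxicity of Four Related Compounds on Rat L6 Cells

The compounds below may be only part of what the source reports. "The series", "measured", "known", "first", "only" and "open" are said of these compounds alone.

Compound 1 `CC(C)NC(=N)c1ccc2cc(-c3cccc(OCCCOc4ccccc4)c3)oc2c1` gives 82300 nM.
Compound 2 `c1ccc(OCCCOc2cccc(-c3cc4ccc(C5=NCCN5)cc4o3)c2)cc1` gives 10100 nM.
Compound 3 `CC(C)NC(=N)c1ccc2cc(-c3cccc(OCCCCCCOc4ccccc4)c3)oc2c1` gives 10100 nM.

These three were read in an ADME assay on L6 cells (Rattus norvegicus) for cytotoxicity, read by resazurin assay, with a stated time of 70 h (on this read-out higher numbers stand for weaker inhibition and lower numbers for stronger inhibition), and compound 4 `c1ccc(OCCCCCCOc2cccc(-c3cc4ccc(C5=NCCN5)cc4o3)c2)cc1` awaits the same measurement. The cores differ in one way: compound 3 carries 3-phenoxypropyl in place of phenoxy on a saturated chain carbon, three bonds along the chain from an oxygen on an aromatic ring, and that single difference gave an 8.1-fold lower number from compound 1 to compound 3 (0.91 log units; beyond the scatter). On the core of compound 1 the change a group of 5 heavy atoms (3 carbon, 2 nitrogen; one five-membered non-aromatic ring with 2 hetero atoms) in place of a group of 6 heavy atoms (4 carbon, 2 nitrogen; no ring), on an aromatic carbon produced an 8.1-fold lower number from compound 1 to compound 2 (0.91 log units; beyond the scatter). The change from compound 3 to compound 4 is a group of 5 heavy atoms (3 carbon, 2 nitrogen; one five-membered non-aromatic ring with 2 hetero atoms) in place of a group of 6 heavy atoms (4 carbon, 2 nitrogen; no ring), on an aromatic carbon, and since its surroundings read the same word for word, it is the same change rather than merely the same kind. Compound 3 stands level with compound 2 at the digits reported, the two together being the lowest of the three numbers. Within the data shown here, a step of the same size would carry compound 4 well past anything measured here, but with only one earlier instance there is no knowing whether the two changes add. A smaller step, a 3.4-fold lower number from compound 3 to compound 4 (0.53 log units; beyond the scatter), is expected, because compound 3 already sits at 10100 nM. Compound 4 is therefore estimated at 3000 nM, somewhere between 900 nM and 10000 nM.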

Compound 4, half-maximal inhibitory concentration: 1800 nM
The estimate for compound 4 lay 1.7-fold (0.22 log units) above the measured number; the range from low to high includes it.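

In this assay, putting the five-membered non-aromatic ring in place of the open group on the aromatic carbon gave a 5.6-fold lower number from compound 3 to compound 4 (0.75 log units; beyond the scatter), and the step kept its size on the two cores: the same change on two cores in this assay, an 8.1-fold lower number (0.91 log units; beyond the scatter) from compound 1 to compound 2 and a 5.6-fold lower number (0.75 log units; beyond the scatter) from compound 3 to compound 4, 1.5-fold (0.16 log units) apart, within the scatter of two such steps

The chain change also carried over, giving a 5.6-fold lower number from compound 2 to compound 4 (0.75 log units; beyond the scatter) on the core that holds the five-membered ring: the same change on two cores in this assay, an 8.1-fold lower number (0.91 log units; beyond the scatter) from compound 1 to compound 3 and a 5.6-fold lower number (0.75 log units; beyond the scatter) from compound 2 to compound 4, 1.5-fold (0.16 log units) apart, within the scatter of two such steps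

Across these four compounds, each change therefore behaved alike on both cores, but that rests on a single pair of cores per change and on this one cell read-out, and it does not show that the steps would hold on any other core or why they arise.

The compounds shown leave open how the number would move with a longer chain than that of compound 3, or with a shorter one than that of compound 1. They also leave open whether a simple amine or a carboxylic acid on the same aromatic carbon would follow the same course.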